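This account rests on a few compounds, and the source may have more. Where it says the series, first, only, none or still open, it means among the compounds named here.

In a functional assay on MCF7 cells (Homo sapiens) for antiproliferative activity, read by MTT assay, with a stated time of 48 h (on this read-out lower numbers stand for stronger inhibition and higher numbers for weaker inhibition), compound 1 (`C#CCCOC(=O)c1ccc(C(CC)(CC)c2ccc(OCCC(O)(CC)CC)c(C)c2)n1CC`) returns only a limit, > 50000 nM and no number. Compound 2 (`CCOC(=O)CN(C)C(=O)c1ccc(C(CC)(CC)c2ccc(OCCC(O)(CC)CC)c(C)c2)n1CC`) stands at 3210 nM and compound 3 (`CCOC(=O)C(CC(=O)OC)NC(=O)c1ccc(C(CC)(CC)c2ccc(OCCC(O)(CC)CC)c(C)c2)n1CC`) at 390 nM as the lowest number of the three. Compound 4 (`CCn1c(C(=O)N(C)CCO)ccc1C(CC)(CC)c1ccc(OCCC(O)(CC)CC)c(C)c1`) departs from compound 3 by one change, a group of 5 heavy atoms (3 carbon, 1 nitrogen, 1 oxygen; no ring) in place of a group of 12 heavy atoms (7 carbon, 1 nitrogen, 4 oxygen; no ring), on a carbonyl carbon and the group that enters is (2-hydroxyethyl)(methyl)amino.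

Every measured step falls on this same carbonyl carbon. Two of them start from a limit (an at least 15-fold lower number from compound 1 to compound 2 (1.19 log units; beyond the scatter) and an at least 120-fold lower number from compound 1 to compound 3 (2.10 log units; beyond the scatter)) and are large, but they give no exact size. The closer guide is the modest step of an 8.2-fold lower number from compound 2 to compound 3 (0.92 log units; beyond the scatter) because compound 2, like compound 4, has a methyl group on the amide nitrogen and lacks the amide hydrogen that compound 3 keeps. Compound 4 also loses both ester groups of compound 3, and the effect of that loss is not known from these compounds. A step of similar size in the opposite direction, toward a higher number, is therefore expected in this assay, and it is estimated as a 10-fold higher number from compound 3 to compound 4 (1.01 log units; beyond the scatter) in this comparison. For compound 4 the estimated value is 4000 nM with an expected range from 1000 nM to 20000 nM in this assay when it is measured.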

Compound 4, half-maximal inhibitory concentration: 2870 nM
Beside the measured number, compound 4's estimate is 1.4-fold (0.14 log units) above it; low and high end bracket the measured number.
By their numbers in this assay, from the lowest: compound 3; then compounds 4 and 2 (each within the scatter of the next). At a limit, above all of these: compound 1.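

In this assay, putting (2-hydroxyethyl)(methyl)amino on the carbonyl carbon in place of the larger ester-bearing group of compound 3 gives a 7.4-fold higher number from compound 3 to compound 4 (0.87 log units; beyond the scatter), so this change moves the number by a modest step beyond the scatter. Hydroxymethyl in place of ethoxycarbonyl on the saturated chain carbon bound to an amide-type nitrogen gives a 1.1-fold lower number from compound 2 to compound 4 (0.05 log units; within the scatter), which shows that, with the methyl group on the amide nitrogen kept, the assay does not tell these two end groups apart. The amide of compound 4 also stands well clear of the ester of compound 1, an at least 17-fold lower number from compound 1 to compound 4 (1.24 log units; beyond the scatter), though the value of compound 1 is a limit and not a number, so this size has no exact value: the limit of > 50000 nM in this assay, at which 1 of the 4 values shown sits.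

The compounds shown do not separate the amide hydrogen of compound 3 from its two ester groups, so it stays open which of these goes with its lower number. Also open, as far as these compounds go, is how a carboxylic acid in place of ethoxycarbonyl, or a longer chain on the amide nitrogen, would read in this assay.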